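Diethylamino for piperidin-1-yl: an expected half-life

The source may hold more compounds than are shown below. What is called first, only, known or untested is meant among the compounds shown, and "the series" means these compounds.

Compound 1 `C/C(=N/c1ccnc2cc(Cl)ccc12)NCCCCN1CCCCC1`: > 1 h
Compound 2 `CC(C)/C(=N/c1ccnc2cc(Cl)ccc12)NCCCCN1CCCCC1`: 0.483 h
Compound 3 `CN(C)CCC/N=C(\c1ccccc1)N(CCCN(C)C)c1ccnc2cc(Cl)ccc12`: > 1 h

In an ADME assay (liver) for metabolic stability, with Liver microsome (Homo sapiens) as the target, read by LC-MS, using microsomes, tested at 1 uM (a lower number here means that the compound disappears faster, a higher number that the compound lasts longer), compound 1 gives > 1 h, which is a limit and not a number. Compound 3 gives > 1 h, which is also a limit. Going by the values given here, compound 2 gives 0.483 h, the only exact value of the three. Compound 1 thus stands at the limit of > 1 h in this assay, at which 2 of the 3 values shown sit.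

Compound 4 `CCN(CC)CCCCN/C(C)=N\c1ccnc2cc(Cl)ccc12` keeps the core of compound 1 and has diethylamino in place of piperidin-1-yl on a saturated chain carbon, four bonds along the chain from an amine nitrogen.

Among the compounds with values here, no measured step makes this change. Within the data shown here, the only measured step, an at least 2.0-fold lower number from compound 1 to compound 2 (0.31 log units; beyond the scatter), places isopropyl in place of methyl on a carbon with a double bond to nitrogen. It shows that this assay can move within this small series, but it does not size the present change. No step beyond the scatter is therefore expected, although a modest fall remains possible: the expected step is a step that the limit leaves unreadable from compound 1 to compound 4. For compound 4 the estimated half-life is 1.2 h, with an expected range of 0.55 h to 2.5 h.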

Compound 4, half-life: > 1 h
Compound 4 was reported as a limit (the forecaster's own chance of this, stated with the estimate: 60%); the middle value does not contradict the limit.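

In this assay compound 4 gives > 1 h, which is a limit and not a number. Compound 1 also stands at a limit, so no step can be read between compound 1 and compound 4: the limit of > 1 h in this assay, at which 3 of the 4 values shown sit.

The compounds shown leave open whether diethylamino in place of piperidin-1-yl changes the half-life at all.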